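The source may hold more compounds than are shown below. What is called first, only, known or untested is meant among the compounds shown, and "the series" means these compounds.

Measured so far:
compound 1, `O=[N+]([O-])c1ccc(O)c(CSc2ncnc3c2ncn3[C@@H]2O[C@H](CO)[C@@H](O)[C@H]2O)c1`, in an assay on isolated protein for binding affinity to Equilibrative nucleoside transporter 1 (Homo sapiens) (on this read-out higher numbers stand for weaker inhibition and lower numbers for stronger inhibition), compound 1 gives 33.1 nM
compound 2, `OC[C@H]1O[C@@H](n2cnc3c(SCCCc4ccccc4)ncnc32)[C@H](O)[C@@H]1O`, compound 2 gives 1350 nM
compound 3, `Cc1ccc(CSc2ncnc3c2ncn3[C@@H]2O[C@H](CO)[C@@H](O)[C@H]2O)cc1`, compound 3 gives 457 nM

Compound 3 stands second highest of the three numbers. Its nearest neighbour is compound 2, separated by a 3.0-fold lower number from compound 2 to compound 3 (0.47 log units; beyond the scatter); its furthest is compound 1, separated by a 14-fold higher number from compound 1 to compound 3 (1.14 log units; beyond the scatter). Both steps to compound 3 are beyond the scatter, so compound 3 sits clearly between the other two.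

Compound 4 is `OC[C@H]1O[C@@H](n2cnc3c(CSc4cccc(I)c4)ncnc32)[C@H](O)[C@@H]1O`. The change from compound 3 is a group of 9 heavy atoms (7 carbon, 1 sulfur, 1 iodine; one six-membered aromatic ring of carbon only) in place of a group of 9 heavy atoms (8 carbon, 1 sulfur; one six-membered aromatic ring of carbon only), on an aromatic carbon.

For the measured compounds named here, two measured steps touch the same position. The step of a 14-fold higher number from compound 1 to compound 3 (1.14 log units; beyond the scatter) shows that exchanging the substituents on the carbon-only ring, with the sulfur-bound chain kept, moves the number a great deal. The step of a 3.0-fold lower number from compound 2 to compound 3 (0.47 log units; beyond the scatter) shows that the length of the chain between sulfur and ring moves it modestly. Going by the values given here, no measured pair replaces a methyl by an iodine, so the direction is open. Since the ring substitution was the stronger lever, a modest step is expected for compound 4, written a 1.5-fold lower number from compound 3 to compound 4 (0.18 log units; within the scatter), and not a large one in either direction. For compound 4 the estimate in this assay is 300 nM, with a range from 90 nM to 1000 nM.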

Compound 4, half-maximal inhibitory concentration: 245 nM
For compound 4 the middle estimate is 1.2-fold (0.09 log units) above the measured one, and the stated range covers the measured number.
By their numbers in this assay, from the lowest: compound 1; then compounds 4 and 3 (each within the scatter of the next); then compound 2.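

In this assay, the exchange of the (4-methylbenzyl)sulfanyl group for the iodine-bearing group gives a 1.9-fold lower number from compound 3 to compound 4 (0.27 log units; within the scatter), so the two compounds cannot be told apart, even though the entering group joins the core through a saturated carbon and holds its sulfur on the carbon-only ring. Within this one pair, then, a sulfur bound directly to the core is not required for a number of this size, but the reversed order of sulfur and carbon and the exchange of methyl for iodine arrive together and cannot be separated. No evidence is available that bears on this result.

Still open, going by these compounds, is whether the hydroxy group, the nitro group or both on the ring of compound 1 account for a 14-fold higher number from compound 1 to compound 3 (1.14 log units; beyond the scatter), since those two groups are exchanged together with the methyl in that step. Also open, on these data alone, are the effects of iodine on the ring of compound 3 with its sulfur linkage kept, and of an amine or an ether oxygen in place of the sulfur in compound 4.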